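This account rests on a few compounds, and the source may have more. Where it says the series, first, only, none or still open, it means among the compounds named here.

Working notes on the series.

Three compounds share one core and differ only in the tail on the chain that hangs from the aromatic oxygen. In a functional assay on ECa-109 cells for inhibition, with ECa-109 cell line (Homo sapiens) as the target, read by MTT assay, with a stated time of 48 h (on this read-out higher numbers stand for weaker inhibition and lower numbers for stronger inhibition), compound 1 `CCN1CCN(C(=S)SCCCOc2ccc3c(=O)c(-c4ccc(OC)cc4)coc3c2)CC1` gives 36900 nM, compound 2 `COc1ccc(-c2coc3cc(OCCCSC(=S)N4CCCC4)ccc3c2=O)cc1` gives 30800 nM, and compound 3 `COc1ccc(-c2coc3cc(OCCCCCBr)ccc3c2=O)cc1` gives 59100 nM. Compound 3 carries the largest of the three numbers, but the gaps are a 1.6-fold higher number from compound 1 to compound 3 (0.20 log units; within the scatter) and a 1.9-fold higher number from compound 2 to compound 3 (0.28 log units; within the scatter), so nothing here separates the three beyond the scatter; the same holds for a 1.2-fold lower number from compound 1 to compound 2 (0.08 log units; within the scatter).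

Compound 4 `COc1ccc(-c2coc3cc(OCCCSC(=S)N4CCOCC4)ccc3c2=O)cc1` has not been measured in this assay. Relative to compound 3 the change is a group of 9 heavy atoms (5 carbon, 1 nitrogen, 1 oxygen, 2 sulfur; one six-membered non-aromatic ring with 2 hetero atoms) in place of a group of 3 heavy atoms (2 carbon, 1 bromine; no ring), on a saturated chain carbon, three bonds along the chain from an oxygen on an aromatic ring.

The two steps that bear on this are those from compound 1 and compound 2 to compound 3, where a ring-bearing thiocarbonyl tail was exchanged for the 2-bromoethyl end; both stayed within the scatter. Compound 4 restores a tail of the same kind, so the number is expected to fall near those of compound 1 and compound 2, without a step beyond the scatter. The expected step is a 1.7-fold lower number from compound 3 to compound 4 (0.24 log units; within the scatter). Compound 4 is therefore estimated at 34000 nM, with a range from 15000 nM to 75000 nM.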

Compound 4, half-maximal inhibitory concentration: 34000 nM
The estimate for compound 4 equals the measured number at the digits printed; the measured number falls inside the stated range.
By their numbers in this assay, from the lowest: compounds 2, 4, 1 and 3 (each within the scatter of the next).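

In this assay, morpholin-4-yl on the thiocarbonyl carbon behaves like the two ring amines already seen there, with steps of a 1.1-fold higher number from compound 2 to compound 4 (0.04 log units; within the scatter) and a 1.1-fold lower number from compound 1 to compound 4 (0.04 log units; within the scatter), so a third ring, this one with a ring oxygen, still gives no separation among the tails. The exchange of the 2-bromoethyl end for this tail, on the saturated chain carbon three bonds along the chain from the oxygen on the aromatic ring, gives a 1.7-fold lower number from compound 3 to compound 4 (0.24 log units; within the scatter), which leaves all four compounds unseparated at this position. Nothing available gives a reason for this flat picture.

Going by these compounds, whether a carboxylic acid or a primary amine at the end of the chain would move the number beyond the scatter stays open. The same holds for a longer chain ahead of the thiocarbonyl carbon.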